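From thiophene to fluorophenyl on the shared core

The source may hold more compounds than are shown below. What is called first, only, known or untested is meant among the compounds shown, and "the series" means these compounds.

Compound 3 `c1cn2cc(-c3ccsc3)nc(-c3ccc4ncn(C5CCCCC5)c4c3)c2n1` gives 12.1% in a functional assay on OVCAR-8 cells (Homo sapiens) for inhibition, read by sulforhodamine B assay, with a stated time of 48 h, tested at 10 uM (a lower number here means less inhibition, a higher number more inhibition at the concentration tested (going by the name of the read-out)), the second highest of three numbers: close to compound 2 `Fc1ccc(-c2cn3ccnc3c(-c3ccc4ncn(C5CCCCC5)c4c3)n2)cc1` with 9.54%, and far beneath compound 1 `c1ccc(-c2cn3ccnc3c(-c3ccc4ncn(C5CCCCC5)c4c3)n2)cc1` with 63.9%. Compound 4 `Fc1ccccc1-c1cn2ccnc2c(-c2ccc3ncn(C4CCCCC4)c3c2)n1` differs from compound 3 in one place: 2-fluorophenyl in place of thiophen-3-yl on an aromatic carbon. Among the compounds with values here, two measured steps bear on this change. Thiophen-3-yl in place of phenyl gave a number 51.8 percentage points lower from compound 1 to compound 3 (beyond the scatter), while fluoro in place of hydrogen on an aromatic carbon gave a number 54.4 percentage points lower from compound 1 to compound 2 (beyond the scatter); the step of a number 2.6 percentage points higher from compound 2 to compound 3 (within the scatter) stayed small. The entering group is a phenyl that carries fluoro, so these two steps point in opposite directions, and for compound 4 only a modest rise is expected, a number 12.9 percentage points higher from compound 3 to compound 4 (beyond the scatter). Compound 4 is therefore estimated at 25%, between 5% and 60%.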

Compound 4, a percentage reported as inhibition, at one concentration (the size of the read-out at that concentration, not a potency): 14.1%
Compound 4: middle estimate off by 10.9 percentage points, on the high side; low and high end bracket the measured number.
By their numbers in this assay, from the lowest: compounds 2, 3 and 4 (each within the scatter of the next); then compound 1.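

Fluoro in place of hydrogen again brings a large fall in this assay, a number 49.8 percentage points lower from compound 1 to compound 4 (beyond the scatter), so the loss is not confined to 4-fluorophenyl. 2-Fluorophenyl in place of 4-fluorophenyl gives a number 4.6 percentage points higher from compound 2 to compound 4 (within the scatter), and 2-fluorophenyl in place of thiophen-3-yl gives a number 2 percentage points higher from compound 3 to compound 4 (within the scatter), so these three groups are not told apart here, and only the plain phenyl of compound 1 stands apart. Nothing measured here explains this. Still open, on these data alone, is whether a phenyl carrying an amine or a methoxy group at this position would stay near compound 1 or fall with the others.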